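The source may hold more compounds than are shown below. What is called first, only, known or untested is meant among the compounds shown, and "the series" means these compounds.

Compound 1 `CNc1nc(SC)nc2ncccc12`: 2920 nM
Compound 2 `CSc1nc(NC2CC2)c2cccnc2n1`: 4900 nM
Compound 3 `CSc1nc(NC2CCCC2)c2cccnc2n1`: 490 nM

These three numbers come from a functional assay (Nicotiana tabacum); a lower number here means a stronger inhibitor, a higher number a weaker inhibitor. Compound 1 stands in the upper part of this small range, with a 1.7-fold higher number from compound 1 to compound 2 (0.22 log units; within the scatter) and a 6.0-fold lower number from compound 1 to compound 3 (0.78 log units; beyond the scatter). The three compounds share a core and differ only in the group on one nitrogen.

Compound 4 `CCCCC(CC)CNc1nc(SC)nc2ncccc12` has not been measured yet. It differs from compound 1 at that same place: 1-ethylpentyl in place of hydrogen on a saturated chain carbon bound to a nitrogen on an aromatic ring.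

All three measured steps change this group, so all three bear on the question. Cyclopentyl in compound 3 goes with a lower number, and the remaining step is a 10-fold lower number from compound 2 to compound 3 (1.00 log units; beyond the scatter). Compound 2 goes against any simple rule that a larger group lowers the number, since its step from compound 1 stays within the scatter. For the measured compounds named here, none of the measured compounds carries an open chain like 1-ethylpentyl, so the comparison is loose.

The best guide is compound 3, with a 6.0-fold lower number from compound 1 to compound 3 (0.78 log units; beyond the scatter), so a drop of similar size is expected, though with wide uncertainty. The expected change is a 4.9-fold lower number from compound 1 to compound 4 (0.69 log units; beyond the scatter). Compound 4 is estimated at 600 nM, with an expected range of 130 nM to 2800 nM.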

Compound 4, half-maximal inhibitory concentration: 15900 nM
Compound 4: the middle estimate sits 27-fold (1.42 log units) below what was measured; measured number above the stated range.
By their numbers in this assay, from the lowest: compound 3; then compounds 1 and 2 (each within the scatter of the next); then compound 4.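

In this assay, placing 1-ethylpentyl on the carbon attached to the nitrogen of compound 1 moves the number the opposite way from the cyclopentyl group, with a 5.4-fold higher number from compound 1 to compound 4 (0.74 log units; beyond the scatter), against a 6.0-fold lower number from compound 1 to compound 3 (0.78 log units; beyond the scatter). Group size alone therefore does not set the number at this position: the cyclopentyl group of compound 3 goes with a lower number than the methyl group of compound 1, whereas the 7-carbon open chain of compound 4 goes with a higher one, and the small cyclopropyl group of compound 2 stays within the scatter of compound 1. Nothing available explains why the ring and the open chain differ in this way.

Four compounds cannot show whether the rise in compound 4 follows from the chain being open, from its branching or from its length, and a straight butyl chain or a cyclohexyl ring on the same nitrogen would help separate these possibilities. As far as these compounds go, it also remains open whether a chain carrying a hydroxyl group or an amine would follow compound 3 or compound 4.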